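The compounds below may be only part of what the source reports. "The series", "measured", "known", "first", "only" and "open" are said of these compounds alone.

Measured so far in an assay on cells for positive allosteric modulation of Cystic fibrosis transmembrane conductance regulator variant F508del (Homo sapiens), with stated times of 10 min and 7 s, in the presence of a further agent that is not named here; on this read-out lower numbers stand for an effect already at smaller amounts and higher numbers for an effect only at larger amounts of compound:
- compound 1 `CC1(C)Cc2c(sc(NC(=O)[C@@H](O)C(C)(C)C)c2C(N)=O)C(C)(C)O1`: 2.7 nM
- compound 2 `Cc1cn[nH]c1C(=O)Nc1sc2c(c1C(N)=O)CC(C)(C)OC2(C)C`: 2 nM

Compound 2 holds the lowest of the two numbers in this assay, but the gap to compound 1 is within the scatter, so the two cannot be ordered. Going by the values given here, the only step measured between them, a 1.4-fold lower number from compound 1 to compound 2 (0.13 log units; within the scatter), replaced an open-chain hydroxy group on the carbonyl carbon with a five-membered aromatic ring without moving the number beyond the scatter.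

Compound 3 `CC1(C)Cc2c(sc(NC(=O)c3cc(C(F)(F)F)n[nH]3)c2C(N)=O)C(C)(C)O1` keeps the shared core and the amide-type nitrogen and changes only the ring on that carbonyl carbon: 3-(trifluoromethyl)-1H-pyrazol-5-yl in place of 4-methyl-1H-pyrazol-5-yl on a carbonyl carbon. Among the compounds with values here, no measured step bears directly on this exchange of one ring substituent for another; the step from compound 1 to compound 2 shows only that this position tolerates a change of group. Compound 3 is therefore expected to stay close to compound 2, with a 1.8-fold higher number from compound 2 to compound 3 (0.24 log units; within the scatter) taken as a step that may lie within the scatter or go modestly toward higher numbers. The estimate for compound 3 in this assay is 3.5 nM, with a range from 1.2 nM to 12 nM.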

Compound 3, half-maximal effective concentration: 3 nM
Compound 3: middle estimate off by 1.2-fold (0.07 log units), on the high side, and the stated range covers the measured number.
By their numbers in this assay, from the lowest: compounds 2, 1 and 3 (each within the scatter of the next).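

On the carbonyl carbon, the exchange of 4-methyl-1H-pyrazol-5-yl for 3-(trifluoromethyl)-1H-pyrazol-5-yl, with 9 heavy atoms entering for 6, gives a 1.5-fold higher number from compound 2 to compound 3 (0.18 log units; within the scatter) in this assay. The earlier step had replaced an open-chain group with a ring, whereas this one shows that the substituent on the ring can also change without a shift beyond the scatter, and a 1.1-fold higher number from compound 1 to compound 3 (0.05 log units; within the scatter) leaves all three compounds unordered. Nothing measured here accounts for how closely these groups agree.

The two pyrazoles differ both in the substituent and in its numbered place on the ring, so the compounds shown do not separate these two changes. As far as these compounds go, it also remains open how an unsubstituted 1H-pyrazol-5-yl, a carboxylic acid or an amine on this carbonyl carbon would read.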